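A Bromopyridine in Place of a Fluoropyridine

This account rests on a few compounds, and the source may have more. Where it says the series, first, only, none or still open, it means among the compounds named here.

Compound 1 `CC1CCN(C2CCN(S(=O)(=O)c3cccnc3F)CC2)CC1` carries a 2-fluoropyridin-3-yl group on its sulfonyl sulfur. In a functional assay on DLD-1 cells (Homo sapiens) for antiproliferative activity, read by CellTiter-Glo, with a stated time of 72 h (a lower number here means a stronger inhibitor, a higher number a weaker inhibitor), compound 1 gives only a limit of the assay, > 5000 nM, and no number. Compound 1 thus stands at the limit of > 5000 nM in this assay, at which 1 of the 2 values shown sits, the weaker end of what has been measured. Among the measured compounds shown here, compound 2 `Cc1cc(C)c(S(=O)(=O)N2CCC(N3CCC(Cc4ccccc4F)CC3)CC2)c(C)c1` differs from compound 1 in several places at once, so no single step connects the two; in this assay compound 2 gives 74 nM. Compound 3 `CC1CCN(C2CCN(S(=O)(=O)c3cncc(Br)c3)CC2)CC1` is the unmeasured partner of compound 1 and differs from it in one place: 5-bromopyridin-3-yl in place of 2-fluoropyridin-3-yl on a sulfonyl sulfur. For the measured compounds named here, with compound 1 reported only as a limit, no measured step exists to set the size of this change. The step from compound 1 to compound 3 is expected to be an at least 1.2-fold lower number from compound 1 to compound 3 (0.09 log units; that floor lies within the scatter), a modest shift toward stronger inhibition that may not clear the scatter. Compound 3 is estimated at 4000 nM, with a range from 1500 nM to 10000 nM.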

Compound 3, half-maximal inhibitory concentration: > 5000 nM
Compound 3: a limit, no number; the forecaster's own chance of this, stated with the estimate: 45%; at least 1.2-fold (0.09 log units) between middle value and limit.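

Among the compounds shown here, compound 1 and compound 3 both give only a limit of the assay and no number, so no step between them can be read: the limit of > 5000 nM in this assay, at which 2 of the 3 values shown sit. The compounds shown leave open whether 5-bromopyridin-3-yl and 2-fluoropyridin-3-yl on a sulfonyl sulfur differ at all in strength of inhibition.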